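A few compounds are considered here, and "the series" means these few. Any claim that something is new, unique, unknown or untested is made for them only; others in the source may bear on it.

Working notes on the series. Compound 1 `COc1ccc(/C=C\C(=O)O)c(OCc2cn(-c3ccc(NC(C)=O)cc3)nn2)c1CC=C(C)C` gives 23400 nM in a functional assay on A-431 cells (Homo sapiens) for cytotoxicity, read by MTT assay, with a stated time of 24 h (on this read-out lower numbers stand for stronger inhibition and higher numbers for weaker inhibition), the lowest of the two numbers, and compound 2 `COc1ccccc1-n1cc(COc2c(/C=C\C(=O)O)ccc(OC)c2CC=C(C)C)nn1` gives 32600 nM; the step of a 1.4-fold higher number from compound 1 to compound 2 (0.14 log units; within the scatter) swaps the aryl group on the aromatic nitrogen. Compound 3 `COc1ccc(/C=C\C(=O)O)c(OCc2cn(-c3ccc(NC(=O)c4ccccc4)cc3)nn2)c1CC=C(C)C` differs from compound 1 by phenyl in place of methyl on a carbonyl carbon. Going by the values given here, no measured step changes the acyl group, so only the within-scatter step from compound 1 to compound 2 bears loosely on it, and no step beyond the scatter is expected in this assay. For compound 3 the expected step is a 1.2-fold lower number from compound 1 to compound 3 (0.07 log units; within the scatter), giving an estimate of 20000 nM with a range of 7000 nM to 60000 nM.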

Compound 3, half-maximal inhibitory concentration: 21200 nM
The estimate for compound 3 lay 1.1-fold (0.03 log units) below the measured number; the measured number falls inside the stated range.
By their numbers in this assay, from the lowest: compounds 3, 1 and 2 (each within the scatter of the next).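

In this assay, phenyl in place of methyl on a carbonyl carbon, acetamido to benzamido, gives a 1.1-fold lower number from compound 1 to compound 3 (0.04 log units; within the scatter) and so stays within the scatter. Going by these compounds alone, this is the first measured change to the acyl group itself, and it shows that a ring of six carbons is carried there without a step beyond the scatter. Nothing at hand gives a reason for this result. Still open, going by these compounds, is whether a carboxylic acid on the phenyl ring, or an aminomethyl group or longer alkyl chain in place of phenyl on the carbonyl carbon, would shift the number beyond the scatter.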